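The source may hold more compounds than are shown below. What is called first, only, known or untested is meant among the compounds shown, and "the series" means these compounds.

Measured so far:
Compound 1 `CCCCCCCC(=O)Nc1ccc2[nH]cc(C3CCN(C)CC3)c2n1` gives 32 nM in an assay for binding affinity to 5-hydroxytryptamine receptor 1B (Homo sapiens), read by radioligand binding; a higher number here means a weaker inhibitor, a lower number a stronger inhibitor.
Compound 2 `Cc1cccc(C(=O)Nc2ccc3[nH]cc(C4CCN(C)CC4)c3n2)c1` gives 1200 nM in this assay.

Compound 1 has the lowest of the two numbers; the only other, compound 2, lies at a 38-fold higher number from compound 1 to compound 2 (1.57 log units; beyond the scatter). Compound 3 `CN1CCC(c2c[nH]c3ccc(NC(=O)Nc4ccc(F)cc4)nc23)CC1` differs from compound 1 in one place: (4-fluorophenyl)amino in place of heptyl on a carbonyl carbon. Within the data shown here, one measured step bears on this: a 38-fold higher number from compound 1 to compound 2 (1.57 log units; beyond the scatter), where an aromatic ring replaced the heptyl on the same carbonyl carbon. Compound 3 likewise trades the heptyl for a group carrying an aromatic ring, so a higher number is expected, of a similar order, a 16-fold higher number from compound 1 to compound 3 (1.19 log units; beyond the scatter). For compound 3 the estimate is 500 nM, expected between 100 nM and 3000 nM.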

Compound 3, inhibition constant: 3.2 nM
Compound 3: the middle estimate sits 160-fold (2.19 log units) above what was measured; measured number outside the range, below it.
By their numbers in this assay, from the lowest: compound 3; then compound 1; then compound 2.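

In this assay, an aromatic ring on this carbonyl carbon does not by itself bring a weaker result: (4-fluorophenyl)amino gives a lower number than heptyl (a 10-fold lower number from compound 1 to compound 3 (1.00 log units; beyond the scatter)) and a far lower one than 3-methylphenyl (a 380-fold lower number from compound 2 to compound 3 (2.57 log units; beyond the scatter)). The ring alone therefore does not set the outcome at this position; the amino link, the ring's substituent, or both must also count. (No evidence at hand explains this result)

Compounds 2 and 3 differ in both features, so their contributions cannot be separated. A plain phenylamino group would help to show what the fluorine adds, while a 3-methylphenylamino group would test the amino link directly.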